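Swapping the amide aryl group in an aldehyde dehydrogenase series

The source may hold more compounds than are shown below. What is called first, only, known or untested is meant among the compounds shown, and "the series" means these compounds.

This account follows three compounds built on one shared core and a fourth that has not yet been measured. Compound 1 `Cc1cccc(Cn2c(CN3CCN(C(=O)c4ccc(Br)cc4)CC3)nc3ccccc32)c1` stands second highest of the three in an assay on isolated protein for inhibition of aldehyde dehydrogenase 1A1 (Homo sapiens), read by spectrophotometry, tested at 10 uM (a lower number here means less inhibition, a higher number more inhibition at the concentration tested (going by the name of the read-out)), where compound 1 gives 25.8%. Its nearest neighbour is compound 3 `O=C(C1CC1)N1CCN(Cc2nc3ccccc3n2Cc2ccccc2)CC1`, which in this assay gives 23.9%, a number within the scatter of compound 1. Furthest away is compound 2 `Cc1ccc(Cn2c(CN3CCN(C(=O)C4CC4)CC3)nc3ccccc32)cc1`, which in this assay gives 51.5%, beyond the scatter above compound 1. Within the data shown here, the only step between measured compounds that differ in one place is a number 27.6 percentage points lower from compound 2 to compound 3 (beyond the scatter), a modest change tied to a hydrogen in place of methyl on an aromatic carbon.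

Compound 4 `Cc1cccc(Cn2c(CN3CCN(C(=O)c4ccco4)CC3)nc3ccccc32)c1` differs from compound 1 by furan-2-yl in place of 4-bromophenyl on a carbonyl carbon. Among the measured compounds shown here, no measured step touches the group on the carbonyl carbon: the single step seen concerns the methyl on the benzyl ring, not the amide aryl group, so it offers no guide in size or direction for this change. With nothing to lean on, the expected step is none beyond the scatter, and compound 4 is expected to sit near compound 1 at 27%, within 12% to 45%, which means an estimated step of a number 1.2 percentage points higher from compound 1 to compound 4 (within the scatter) in this assay.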

Compound 4, a percentage reported as inhibition, at one concentration (the size of the read-out at that concentration, not a potency): 73.2%
The estimate for compound 4 lay 46.2 percentage points below the measured number; the whole stated range lies below it.
By their numbers in this assay, from the lowest: compounds 3 and 1 (each within the scatter of the next); then compound 2; then compound 4.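

Among these compounds, the group on the carbonyl carbon turns out to matter a great deal in this assay: there is a number 47.4 percentage points higher from compound 1 to compound 4 (beyond the scatter), a large step at a place that no earlier pair had touched, since the only earlier step concerned the methyl on the benzyl ring. The change swaps 4-bromophenyl, with its 7 heavy atoms and a six-membered aromatic ring of carbon only, for furan-2-yl, with 5 heavy atoms, a five-membered aromatic ring and 1 hydrogen-bond acceptor, and all of these differences arrive together, so the step cannot be assigned to any one of them. No supporting information bears on why the number moves so far.

Going by these compounds, it remains open whether the loss of bromine, the smaller ring or the ring oxygen carries the step, a question that plain phenyl or thiophen-2-yl on the same carbonyl carbon could begin to separate. Also open, on these data alone, is whether furan-2-yl would give a step of similar size on a core without the methyl on the benzyl ring, such as that of compound 3.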